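Replacement of methyl by a sulfur-bearing group on the shared core

The compounds below may be only part of what the source reports. "The series", "measured", "known", "first", "only" and "open" are said of these compounds alone.

Measured so far in an assay on HEK293 cells for binding affinity to Neuronal acetylcholine receptor; alpha4/beta2 (Homo sapiens); on this read-out lower numbers stand for stronger inhibition and higher numbers for weaker inhibition:
- compound 1, `c1nc2cc3c(cc2[nH]1)C1CNCC3C1`: 0.15 nM
- compound 2, `Cc1ccc2c(c1)C1CNCC2C1`: 1.6 nM

Compound 2 holds the highest of the two numbers in this assay; its nearest neighbour is compound 1, whose number is lower by a margin beyond the usual scatter. Within the data shown here, the two differ in more than one place, so their values alone show only that compound 1 is the tighter binder of the pair.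

Compound 3, `O=S(=O)(c1ccc2c(c1)C1CNCC2C1)N1CC1`, is not yet measured. It differs from compound 2 by a group of 6 heavy atoms (2 carbon, 1 nitrogen, 2 oxygen, 1 sulfur; one three-membered non-aromatic ring with 1 hetero atom) in place of one carbon atom, on an aromatic carbon. The group that enters is larger than the methyl it replaces and brings two hydrogen-bond acceptors where there were none.

Among the measured compounds shown here, no step between measured compounds mirrors this change, so the expectation rests on compound 2 alone. A step somewhat beyond the scatter, towards a higher number, is expected for compound 3, as a 3.1-fold higher number from compound 2 to compound 3 (0.49 log units; beyond the scatter). Compound 3 is therefore estimated at 5 nM in this assay, within a range from 1 nM to 30 nM.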

Compound 3, inhibition constant: 2 nM
Estimate against measurement, compound 3: 2.5-fold (0.40 log units) above; low and high end bracket the measured number.
By their numbers in this assay, from the lowest: compound 1; then compounds 2 and 3 (each within the scatter of the next).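

In this assay, among these compounds, putting the group of 6 heavy atoms with its three-membered non-aromatic ring in place of methyl gives a 1.3-fold higher number from compound 2 to compound 3 (0.10 log units; within the scatter), the first step that differs in one place only. On this aromatic carbon, meta to a fused ring and para to a fused ring, a much larger group with 2 hydrogen-bond acceptors therefore leaves the number within the scatter of the methyl compound, so in this one pair neither the added heavy atoms nor the acceptors separate the two compounds. No measurement at hand bears on why the two numbers stay together.

As far as these compounds go, whether an amine, a carboxylic acid or a longer chain on the same aromatic carbon would also stay within the scatter of compound 2 remains open, since a single step cannot show how far this latitude extends. Among the compounds shown here, also open is whether any group at this carbon can bring the number towards that of compound 1 at 0.15 nM, which differs from compound 2 in more than one place and so offers no step to read.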